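The source may report more compounds than this note shows. Statements on the series, on what has been measured and on what is new or still open speak of the compounds shown alone.

Measured compounds in a functional assay on LoVo cells (Homo sapiens) for inhibition, read by MTT assay, with a stated time of 48 h; on this read-out lower numbers stand for stronger inhibition and higher numbers for weaker inhibition:

compound 1, `COc1ccc(N(C)c2nc(C)nc3ccccc23)cc1C(=O)NCC[Se]C#N` — 561 nM
compound 2, `Cc1nc(N(C)c2ccc([Se]C#N)c(F)c2)c2ccccc2n1` — 13 nM
compound 3, `CN(c1ccc([Se]C#N)cc1)c1nc(C2CC2)nc2ccccc12` — 11 nM

Compound 1 stands highest of the three numbers in this assay. Compound 2 is nearest to it and compound 3 furthest, and both gaps lie beyond the usual scatter, so compound 1 is the weakest inhibitor of the three. Compounds 2 and 3 sit within the scatter of each other and are not ordered.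

Compound 4, `COc1ccc(N(C)c2nc(C)nc3ccccc23)cc1OCCC[Se]C#N`, has not been measured. It differs from compound 1 at one place: a group of 7 heavy atoms (4 carbon, 1 nitrogen, 1 oxygen, 1 selenium; no ring) in place of a group of 8 heavy atoms (4 carbon, 2 nitrogen, 1 oxygen, 1 selenium; no ring), on an aromatic carbon The group that leaves carries one hydrogen-bond donor and one double bond outside aromatic rings; the group that enters carries neither, while keeping the triple bond and the selenium. Going by the values given here, no pair of measured compounds shows this change, and compounds 2 and 3 differ from compound 1 at several places at once, so their values give no direct guide to it.

Among the compounds with values here, with no comparable step on record, only a modest step from compound 1 to compound 4 in this assay is expected, estimated at a 1.4-fold lower number from compound 1 to compound 4 (0.15 log units; within the scatter), toward a somewhat lower number but not clearly beyond the scatter. Compound 4 is therefore expected to give about 400 nM, within a range of 100 nM to 1500 nM.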

Compound 4, half-maximal inhibitory concentration: 921 nM
The estimate for compound 4 lay 2.3-fold (0.36 log units) below the measured number; the range from low to high includes it.
By their numbers in this assay, from the lowest: compounds 3 and 2 (each within the scatter of the next); then compounds 1 and 4 (each within the scatter of the next).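

In this assay, on an aromatic carbon ortho to a methoxy group, placing the group of 7 heavy atoms with 0 hydrogen-bond donors where the group of 8 heavy atoms with 1 hydrogen-bond donor stood gives a 1.6-fold higher number from compound 1 to compound 4 (0.22 log units; within the scatter). Going by these compounds alone, this is the first step on record at this place, and it shows that, on the core of compound 1, losing the hydrogen-bond donor and the double bond outside aromatic rings together, while keeping the triple bond and the selenium, leaves the number within the usual scatter. No measurement on hand bears on why this exchange leaves the number there.

The donor and the double bond left in a single step, so the compounds shown do not separate their contributions, and they give no second example of this change on another core. Also open, as far as these compounds go, is how the number at this place would respond to a longer chain, or to a chain ending in an amine or a carboxylic acid in place of the selenium-bearing nitrile end.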